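Chloro for fluoro in a bis-furan amidine, hemolysis expected

The compounds below may be only part of what the source reports. "The series", "measured", "known", "first", "only" and "open" are said of these compounds alone.

Measured compounds:
compound 1 `N=C(N)c1ccc(-c2ccc(-c3cncc4ccccc34)s2)s1`: "non-toxic" (no number reported)
compound 2 `N=C(N)c1ccc(-c2ccc(-c3ccc(F)cc3)o2)o1`: 17.6%

Compound 1 `N=C(N)c1ccc(-c2ccc(-c3cncc4ccccc34)s2)s1` is described only in words in an ADME assay on cells (Erythrocyte, Homo sapiens) for activation, read by hemolysis, with a stated time of 30 min, tested at 2.5 mM (a lower number here means a weaker effect, a higher number a stronger effect of the compound at the concentration tested), and compound 1 gives "non-toxic" (no number reported) there without a number. Among the measured compounds shown here, compound 2 `N=C(N)c1ccc(-c2ccc(-c3ccc(F)cc3)o2)o1` is the only compound with a number in this assay, so compound 2 stands alone and has no neighbour to rank against; in this assay compound 2 gives 17.6%.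

Compound 3 `N=C(N)c1ccc(-c2ccc(-c3ccc(Cl)cc3)o2)o1` differs from compound 2 in one place: chloro in place of fluoro on an aromatic carbon. For the measured compounds named here, no step between two measured compounds is available, so the size of the change can only be guessed from the single number. A shift from compound 2 to compound 3 of a number 4.4 percentage points higher from compound 2 to compound 3 (within the scatter) is expected, which does not go beyond the usual scatter. On that basis compound 3 is estimated to give 22% in this assay, with a range from 8% to 40%.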

Compound 3, a percentage reported as activity, at one concentration (the size of the read-out at that concentration, not a potency): 41.3%
Beside the measured number, compound 3's estimate is 19.3 percentage points below it; measured number outside the range, above it.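

Among the compounds shown here, changing fluoro to chloro on the aromatic carbon para to a large group gives a number 23.7 percentage points higher from compound 2 to compound 3 (beyond the scatter) in this assay and is the only step that can be read so far. It shows that this position is not silent in this read-out: one halogen replacing another, with no ring, hydrogen-bond donor, hydrogen-bond acceptor or net charge entering or leaving, moves the result beyond the scatter. Nothing measured here bears on why the read-out moves at this position.

The compounds shown leave open whether the read-out keeps rising with bromo at this position, or how a methoxy group or an amine there would compare with chloro. They also leave open whether the same exchange would give a step of similar size on any other core.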